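Hydrogen in place of methyl on compound 3

The source may report more compounds than this note shows. Statements on the series, on what has been measured and on what is new or still open speak of the compounds shown alone.

In an ADME assay on microsomes from liver (Homo sapiens) for metabolic stability (on this read-out lower numbers stand for a shorter-lived compound and higher numbers for a longer-lived compound), compound 1 `COc1ccc(Nc2cc3c(cn2)ncn3CC2CC2)c(OC)c1` gives 0.233 h and compound 2 `Cc1nc2cc(Nc3cc4c(cn3)ncn4CC3CC3)ccc2o1` gives 0.633 h. Compound 3 `CN1C(=O)COc2cc(Nc3cc4c(cn3)ncn4CC3CC3)ccc21` gives > 1.66 h, which is a limit and not a number. It is the only one of the three reported this way: the limit of > 1.66 h in this assay, at which 1 of the 3 values shown sits.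

Compound 4 `O=C1COc2cc(Nc3cc4c(cn3)ncn4CC3CC3)ccc2N1` carries hydrogen in place of methyl on an amide-type nitrogen in a ring. Within the data shown here, no two measured compounds differ in one place, so no measured step serves as a guide. A small step towards a shorter half-life is expected in this assay. The estimated step is an at least 1.1-fold lower number from compound 3 to compound 4 (0.07 log units; that floor lies within the scatter). For compound 4 the expected half-life is 1.4 h, with an estimated range of 0.7 h to 2.8 h.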

Compound 4, half-life: > 1.66 h
Compound 4: no number, only a limit; the forecaster's own chance of this, stated with the estimate: 45%; at least 1.1-fold (0.07 log units) between middle value and limit.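

Compound 3 and compound 4 both stand as limits and not as numbers, so no step can be read between them: the limit of > 1.66 h in this assay, at which 2 of the 4 values shown sit.

The compounds shown leave open whether hydrogen in place of methyl on the amide-type nitrogen changes the half-life at all.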